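This account rests on a few compounds, and the source may have more. Where it says the series, first, only, none or still open, it means among the compounds named here.

Measured so far in a functional assay on BXPC-3 cells (Homo sapiens) for inhibition, read by MTT assay, with a stated time of 7 days; on this read-out lower numbers stand for stronger inhibition and higher numbers for weaker inhibition:

compound 1 `CCOC(=O)[C@@H]1CCCN(S(=O)(=O)c2ccc(S(=N)(=O)N(CC)CC)cc2)C1`: 3600 nM
compound 2 `CCN(CC)S(=O)(=O)c1ccc(S(=O)(=O)N2CCC[C@@H](C(=O)NC3CN(C(=O)NC(C)(C)C)C3)C2)cc1`: 10100 nM
compound 3 `CCN(CC)S(=O)(=O)c1ccc(S(=O)(=O)N2CCC[C@@H](C(=O)N3CCN(C(=O)OC(C)(C)C)CC3)C2)cc1`: 200 nM

Compound 1 sits at the second highest of the three numbers. Compound 2 gives a higher number, beyond the scatter, and compound 3 gives a much lower number, also beyond the scatter. Within the data shown here, both compound 2 and compound 3 differ from compound 1 in what replaces the ethyl ester on the shared core, not in the aryl substituent; no measured pair in this assay isolates a change at that substituent.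

Compound 4 `CCOC(=O)[C@@H]1CCCN(S(=O)(=O)c2ccc(C(=O)N(CC)CC)cc2)C1` keeps the core of compound 1 and changes one group: a group of 7 heavy atoms (5 carbon, 1 nitrogen, 1 oxygen; no ring) in place of a group of 8 heavy atoms (4 carbon, 2 nitrogen, 1 oxygen, 1 sulfur; no ring), on an aromatic carbon. Among the measured compounds shown here, with no measured step to anchor this change, the step in this assay is expected to be small, in either direction, and not clearly beyond the scatter. Compound 4 is therefore estimated at 4000 nM, with a range from 1500 nM to 12000 nM. The expected step is a 1.1-fold higher number from compound 1 to compound 4 (0.05 log units; within the scatter), and the range is set wide to reflect the absence of a directly comparable pair.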

Compound 4, half-maximal inhibitory concentration: 640 nM
Estimate against measurement, compound 4: 6.3-fold (0.80 log units) above; the measured number lies below the stated range.
By their numbers in this assay, from the lowest: compound 3; then compound 4; then compound 1; then compound 2.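

In this assay, among these compounds, the aromatic carbon para to a large group proves to be a position that responds to substitution: diethylcarbamoyl in place of the leaving group of 8 heavy atoms gives a 5.6-fold lower number from compound 1 to compound 4 (0.75 log units; beyond the scatter), the first step that isolates a change there. The change also takes the count of hydrogen-bond donors on this substituent from 1 to 0, but this single pair cannot separate that difference from the others between the two groups. No supporting data bear on the origin of the step.

Open, from the compounds shown here alone, is whether a smaller dimethylcarbamoyl or a carboxylic acid at this position would keep the lower number. Also open, going by these compounds, is whether the step carries over when an amide replaces the ethyl ester on the shared core.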